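The compounds below may be only part of what the source reports. "The series", "measured", "known", "first", "only" and "open" are said of these compounds alone.

Measured compounds in the series:

Compound 1, `O=C1Nc2ccc(F)cc2/C1=C\c1cccc(OCc2cn(Cc3ccccc3)nn2)c1`. In a functional assay on PC-3 cells (Homo sapiens) for inhibition, read by MTT assay, with a stated time of 48 h (on this read-out lower numbers stand for stronger inhibition and higher numbers for weaker inhibition), compound 1 gives > 50000 nM, which is a limit of the assay and not a number.

Compound 2, `CC(=O)c1ccc2c(c1)/C(=C\c1cccc(OCc3cn(Cc4ccccc4)nn3)c1)C(=O)N2`. In this assay compound 2 gives > 50000 nM, again a limit and not a number.

Compound 2 therefore stands at the limit, as does compound 1; the step from compound 1 to compound 2 reads a step that the two limits leave unreadable from compound 1 to compound 2, and the limit of > 50000 nM in this assay, at which 2 of the 2 values shown sit, covers both values shown.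

Compound 3, `O=C1Nc2ccc(C(=O)c3ccccc3)cc2/C1=C\c1cccc(OCc2cn(Cc3ccccc3)nn2)c1`, is compound 2 with phenyl in place of methyl on a carbonyl carbon. Going by the values given here, the only measured step, from compound 1 to compound 2, is unreadable, so no measured step sets a size or direction for this change. The step from compound 2 to compound 3 is expected to be a step that the limit leaves unreadable from compound 2 to compound 3, with the result most likely again a limit. Compound 3 is estimated at 60000 nM, with a range from 15000 nM to 250000 nM.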

Compound 3, half-maximal inhibitory concentration: > 50000 nM
Compound 3: no number, only a limit; the forecaster's own chance of this, stated with the estimate: 80%; the middle value does not contradict the limit.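

Compound 3 gives > 50000 nM in this assay, a limit and not a number. No step among compound 1, compound 2 and compound 3 can be read, as all three rest on one limit: the limit of > 50000 nM in this assay, at which 3 of the 3 values shown sit.

The compounds shown leave open whether any of these substituents changes inhibition in this assay, since none gives a number.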